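Cyclobutyl for propyl on an acyl series without measurable potency

The source may report more compounds than this note shows. Statements on the series, on what has been measured and on what is new or still open speak of the compounds shown alone.

Compound 1, `Cc1[nH]nc(N)c1-c1ccc(Br)cc1`, gives in an assay on Sf9 cells for inhibition of inhibitor of nuclear factor kappa-B kinase subunit epsilon (Homo sapiens), read by ADP-Glo, with a stated time of 60 min (a higher number here means a weaker inhibitor, a lower number a stronger inhibitor), a value that is a limit of the assay: > 100000 nM.
Compound 2, `CC(=O)n1nc(C)c(-c2ccc(Cl)c(Cl)c2)c1N`, gives a limit as well: > 100000 nM.
Compound 3, `CCCC(=O)n1nc(C)c(-c2ccc(Cl)c(Cl)c2)c1N`, likewise gives only a limit: > 100000 nM.

Compound 3 therefore stands at the limit of this assay, together with every other measured compound; the three values are no more than limits, and none can be ordered against another. Among the compounds with values here, the one measured step that changes a single place, a step that the two limits leave unreadable from compound 2 to compound 3, cannot be read for the same reason, since both its ends are limits. The evidence on the measured steps comes down to a single observation: the limit of > 100000 nM in this assay, at which 3 of the 3 values shown sit.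

Compound 4, `Cc1nn(C(=O)C2CCC2)c(N)c1-c1ccc(Cl)c(Cl)c1`, differs from compound 3 in one place: cyclobutyl in place of propyl on a carbonyl carbon. Within the data shown here, no measured step bears on a change of this kind, and the only step recorded is unreadable. Among the measured compounds shown here, nothing among the measured values gives a direction, so no step beyond the scatter can be expected, and the most likely outcome is that compound 4 again returns only a limit. The expected step from compound 3 to compound 4 is accordingly a number no higher from compound 3 to compound 4 (the limit leaves the size open). Compound 4 is estimated at 100000 nM in this assay, with a range from 30000 nM to 300000 nM.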

Compound 4, half-maximal inhibitory concentration: > 100000 nM
Compound 4: no number, only a limit; the forecaster's own chance of this, stated with the estimate: 85%; the middle value sits exactly at the limit.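

In this assay compound 4 gives > 100000 nM as a limit of the assay. The steps to compound 4 from compound 2 and from compound 3 join limits and cannot be read. The compounds shown leave open whether any acyl group on the shared core gives a measurable half-maximal inhibitory concentration: the limit of > 100000 nM in this assay, at which 4 of the 4 values shown sit.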